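The compounds below may be only part of what the source reports. "The series", "measured", "known", "first", "only" and "open" are said of these compounds alone.

Two compounds have been measured in a functional assay on SMMC-7721 cells (Homo sapiens) for inhibition, read by MTT assay, with a stated time of 48 h; on this read-out lower numbers stand for stronger inhibition and higher numbers for weaker inhibition:
Compound 1 `CN(c1ncccc1CNc1nc(Nc2ccc3c(c2)CC(=O)N3)nc2[nH]cc(F)c12)S(C)(=O)=O` gives 73200 nM.
Compound 2 `CN(c1ncccc1CNc1nc(Nc2ccc3c(c2)CC(=O)N3)nc2[nH]cc(Cl)c12)S(C)(=O)=O` gives 21900 nM.

Among the measured compounds shown here, compound 1 stands highest of the two numbers, and the only step measured is a 3.3-fold lower number from compound 1 to compound 2 (0.52 log units; beyond the scatter). Compound 3 `COc1cc(Nc2nc(NCc3cccnc3N(C)S(C)(=O)=O)c3c(F)c[nH]c3n2)cc(OC)c1OC` differs from compound 1 as follows: a group of 12 heavy atoms (9 carbon, 3 oxygen; one six-membered aromatic ring of carbon only) in place of a group of 10 heavy atoms (8 carbon, 1 nitrogen, 1 oxygen; one five-membered non-aromatic ring with 1 hetero atom, one six-membered aromatic ring of carbon only), on a nitrogen on an aromatic ring. For the measured compounds named here, the measured step concerns only the halogen and does not touch this position, so no measured step bears on the change; the numbers show only that compound 1 is the weaker of the two. Compound 3 is therefore expected to show a step of a 1.2-fold lower number from compound 1 to compound 3 (0.09 log units; within the scatter), with a wide range. The estimate for compound 3 in this assay is 60000 nM, within 15000 nM to 250000 nM.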

Compound 3, half-maximal inhibitory concentration: > 100000 nM
Compound 3: no number, only a limit (the forecaster's own chance of this, stated with the estimate: 20%); at least 1.6-fold (0.22 log units) between middle value and limit.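

On a nitrogen on an aromatic ring, 3,4,5-trimethoxyphenyl in place of the group carried by compound 1 brought no stronger inhibition in this assay, the change reading as an at least 1.3-fold higher number from compound 1 to compound 3 (0.13 log units; that floor lies within the scatter). In this assay compound 3 gives > 100000 nM, which is a limit and not a number. The true size of the step stays unknown because the read-out ends at that limit: the limit of > 100000 nM in this assay, at which 1 of the 3 values shown sits.

Still open, going by these compounds, is how a plain phenyl or a piperazine-bearing phenyl on this nitrogen would read. Also open, on these data alone, is whether chloro in place of fluoro would lower the number with 3,4,5-trimethoxyphenyl present.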